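Spiro series, triazolylmethyl amides: antiproliferative readings at the limit

This account rests on a few compounds, and the source may have more. Where it says the series, first, only, none or still open, it means among the compounds named here.

Measured compounds:
compound 1, `N#CC1=C(N)Oc2c(c3nc4ccccc4nc3c3ccccc23)C12C(=O)N(Cc1cnnn1-c1ccc(S(N)(=O)=O)cc1)c1ccccc12`, > 50000 nM
compound 2, `N#CC1=C(N)Oc2c(N)cc3nc4ccccc4nc3c2C12C(=O)N(Cc1cnnn1-c1ccc(Cl)cc1)c1ccccc12`, > 50000 nM

In a functional assay on MCF7 cells (Homo sapiens) for antiproliferative activity, read by MTT assay, with a stated time of 48 h (a higher number here means a weaker inhibitor, a lower number a stronger inhibitor), compound 1 gives > 50000 nM, which is a limit of the assay and not a number. In this assay compound 2 likewise gives > 50000 nM, again a limit rather than a measured value. Both readings therefore sit at the same point, as the evidence shows: the limit of > 50000 nM in this assay, at which 2 of the 2 values shown sit. Nothing in these two compounds separates them, and no ordering between them can be stated.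

Compound 3, `CCOc1ccccc1-n1nncc1CN1C(=O)C2(C(C#N)=C(N)Oc3c(N)cc4nc5ccccc5nc4c32)c2ccccc21`, has not yet been measured in this assay. Its structural change from compound 2 is 2-ethoxyphenyl in place of 4-chlorophenyl on an aromatic nitrogen. The 4-chlorophenyl leaves and the 2-ethoxyphenyl enters, on an aromatic nitrogen of the five-membered aromatic ring with three nitrogens.

For the measured compounds named here, no measured step in this assay is available for any pair of compounds here, so the size of the step cannot be read from data. Since compound 2 gives only a limit, the step that the limit leaves unreadable from compound 2 to compound 3 is expected to stay within the scatter, with a further limit the most probable outcome. For compound 3 the expected value is 60000 nM, within 20000 nM to 200000 nM.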

Compound 3, half-maximal inhibitory concentration: > 50000 nM
Compound 3 gave a limit, no number; the forecaster's own chance of this, stated with the estimate: 80%; the middle value lies beyond the limit too.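

In this assay compound 3 gives > 50000 nM, a limit and not a number. Compound 2 also stands at a limit, so no step can be read between compound 2 and compound 3. The compounds shown leave open whether any group on the aromatic nitrogen would give a numerical reading in this assay: the limit of > 50000 nM in this assay, at which 3 of the 3 values shown sit.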